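This account rests on a few compounds, and the source may have more. Where it says the series, first, only, none or still open, it means among the compounds named here.

Measured compounds in an assay on HEK293 cells for displacement of a labelled ligand from growth hormone secretagogue receptor type 1 (Homo sapiens), with a stated time of 60 min; on this read-out higher numbers stand for weaker inhibition and lower numbers for stronger inhibition:
- compound 1, `COc1cccc(-n2cc3nc(-c4cccnc4C)n(C[C@H]4CCCN(CC5CCCC5)C4)c(=O)c3n2)c1`: 12 nM
- compound 2, `CCO[C@H](C)CN1CCC[C@H](Cn2c(-c3cccnc3C)nc3cn(-c4cccc(OC)c4)nc3c2=O)C1`: 40 nM
- compound 3, `COc1cccc(-n2cc3nc(-c4cccnc4C)n(C[C@H]4CCCN(CC(C)C)C4)c(=O)c3n2)c1`: 5.7 nM

Compound 3 gives the lowest number of the three in this assay, with compound 1 nearest to it and compound 2 furthest; both steps to it lie beyond the scatter: a 2.1-fold lower number from compound 1 to compound 3 (0.32 log units; beyond the scatter) and a 7.0-fold lower number from compound 2 to compound 3 (0.85 log units; beyond the scatter).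

Compound 4, `CCO[C@@H](C)CN1CCC[C@H](Cn2c(-c3cccnc3C)nc3cn(-c4cccc(OC)c4)nc3c2=O)C1`, is not yet measured. Its change from compound 3 is 1-ethoxyethyl in place of isopropyl on a saturated chain carbon bound to an amine nitrogen in a ring. Compound 2 carries the same 1-ethoxyethyl group, with the opposite configuration at its defined stereocentre, on the same saturated chain carbon bound to an amine nitrogen in a ring.

Within the data shown here, the steps that bear on this change are a 7.0-fold lower number from compound 2 to compound 3 (0.85 log units; beyond the scatter), which is the exact reversal of the group exchange though with the other stereocentre, and a 3.3-fold higher number from compound 1 to compound 2 (0.52 log units; beyond the scatter), which also shows the 1-ethoxyethyl group giving the higher number. Both point to a higher number for compound 4 than for compound 3 in this assay. Among the measured compounds shown here, the opposite configuration leaves the size open, so the expected step is smaller than the one seen with compound 2 and is given a wide range.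

For compound 4 the estimated step is a 3.9-fold higher number from compound 3 to compound 4 (0.59 log units; beyond the scatter). Compound 4 is therefore expected to give about 22 nM in this assay, in a range from 7 nM to 70 nM.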

Compound 4, half-maximal inhibitory concentration: 5 nM
The estimate for compound 4 lay 4.4-fold (0.64 log units) above the measured number, outside the stated range (below it).
By their numbers in this assay, from the lowest: compounds 4 and 3 (each within the scatter of the next); then compound 1; then compound 2.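

In this assay, 1-ethoxyethyl on this saturated chain carbon is not tied to a higher number, since its exchange for isopropyl gives a 1.1-fold lower number from compound 3 to compound 4 (0.06 log units; within the scatter) and leaves the two compounds unseparated. The earlier gap for this group instead belongs to one configuration, and an 8.0-fold lower number from compound 2 to compound 4 (0.90 log units; beyond the scatter) can be set on the stereocentre alone, drawn R in compound 2 and S in compound 4, because of one fact: the fact that compounds 2 and 4 differ only in the configuration as drawn. With the S form, the comparison with cyclopentyl also reverses the direction seen for the R form, giving a 2.4-fold lower number from compound 1 to compound 4 (0.38 log units; beyond the scatter), so the ranking of 1-ethoxyethyl against the other groups at this place depends on its drawn configuration.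

The compounds shown leave open whether the S form keeps its advantage over the R form when the ethoxy part is replaced, for instance by a methoxy group, a longer alkoxy chain or an amine. They also leave open whether the ether oxygen matters at all, a question that an all-carbon chain such as sec-pentyl, in both configurations, would address.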